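From 3-ethoxyphenyl to 3-methylphenyl

The source may report more compounds than this note shows. Statements on the series, on what has been measured and on what is new or still open speak of the compounds shown alone.

Among the compounds with values here, in a functional assay on MDA-MB-231 cells (Homo sapiens) for antiproliferative activity, read by MTT assay, with a stated time of 48 h (on this read-out lower numbers stand for stronger inhibition of growth and higher numbers for weaker inhibition of growth), compound 3 (`CCOc1cccc(C2=NN(C(=O)OC)C(c3cc(OC)c(OC)c(OC)c3)C2)c1`) gives 190 nM, the lowest number so far but not clear of compound 1 (`COC(=O)N1N=C(c2cccc(OC)c2)CC1c1cc(OC)c(OC)c(OC)c1`) at 350 nM. Compound 2 (`COC(=O)N1N=C(c2cccc(O)c2)CC1c1cc(OC)c(OC)c(OC)c1`) gives 740 nM.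

Compound 4 (`COC(=O)N1N=C(c2cccc(C)c2)CC1c1cc(OC)c(OC)c(OC)c1`) is unmeasured and carries methyl in place of ethoxy on an aromatic carbon, meta to a large group: methyl in place of ethoxy on an aromatic carbon.

Within the data shown here, no measured step replaces ethoxy with methyl, so the evidence is indirect. All three measured compounds keep an oxygen at this place. The series shows a 1.8-fold lower number from compound 1 to compound 3 (0.27 log units; within the scatter), which stays within the scatter. It also shows a 2.1-fold higher number from compound 1 to compound 2 (0.33 log units; beyond the scatter) and a 3.9-fold lower number from compound 2 to compound 3 (0.59 log units; beyond the scatter), both modest and beyond it. These steps span a small range, which suggests a modest change rather than a large one. The loss of ethoxy points, tentatively, towards a higher number. The expected step is a 2.1-fold higher number from compound 3 to compound 4 (0.32 log units; beyond the scatter), close to the edge of the scatter. The estimated value for compound 4 is 400 nM, with an expected range of 150 nM to 1000 nM.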

Compound 4, concentration for 50% growth inhibition: 140 nM
Compound 4: the middle estimate sits 2.9-fold (0.46 log units) above what was measured, and the stated range ends above it.
By their numbers in this assay, from the lowest: compounds 4, 3 and 1 (each within the scatter of the next, the first and the last beyond it); then compound 2.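

In this assay, an oxygen on this aromatic carbon proves not to be required, since all earlier compounds carried one and the change to a plain methyl gives a 1.4-fold lower number from compound 3 to compound 4 (0.13 log units; within the scatter). The methyl compound also stands clear of the two smaller oxygen groups, with a 2.5-fold lower number from compound 1 to compound 4 (0.40 log units; beyond the scatter) and, from the hydroxy compound, a 5.3-fold lower number from compound 2 to compound 4 (0.72 log units; beyond the scatter), so the ethoxy and methyl compounds share a level that neither the methoxy nor the hydroxy compound reaches. Nothing measured here accounts for these differences.

Open, as far as these compounds go, is how a bare hydrogen, a chlorine, an amine or a carboxylic acid on this carbon would compare. Also open, from the compounds shown here alone, is whether a longer chain, such as propyl or propoxy, would stay at this level.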